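A few compounds are considered here, and "the series" means these few. Any claim that something is new, unique, unknown or untested is made for them only; others in the source may bear on it.

Results in an ADME assay on microsomes from liver (Homo sapiens) for metabolic stability (a higher number here means faster removal of the compound, a lower number slower removal), for the measured compounds:
- Compound 1 `CC(C)Oc1cc(Oc2ccc(S(C)(=O)=O)cc2)cc(-c2cncc(=O)[nH]2)c1` gives 11 mL/min/kg
- Compound 2 `CC(C)Oc1cc(Oc2cnc(C(=O)N(C)C)nc2)cc(-c2nccc(=O)[nH]2)c1` gives < 8 mL/min/kg as a limit of the assay
- Compound 3 `CCS(=O)(=O)c1ccc(Oc2cc(O[C@@H](C)CO)cc(-c3nccc(=O)[nH]3)c2)cc1` gives < 8 mL/min/kg as a limit of the assay

Within the data shown here, compound 1 gives 11 mL/min/kg as the only true number here. The other two results are limits. Compound 4 `CCc1cnc(-c2cc(Oc3ccc(S(C)(=O)=O)cc3)cc(OC(C)C)c2)[nH]c1=O` differs from compound 1 in one place: a group of 9 heavy atoms (6 carbon, 2 nitrogen, 1 oxygen; one six-membered aromatic ring with 2 hetero atoms) in place of a group of 7 heavy atoms (4 carbon, 2 nitrogen, 1 oxygen; one six-membered aromatic ring with 2 hetero atoms), on an aromatic carbon on an aromatic carbon of a six-membered aromatic ring of carbon only, meta to a large group and meta to an isopropoxy group. Among the measured compounds shown here, no measured pair shows the effect of such a change in this assay so the expectation rests on the change alone. The expected step of a 1.3-fold higher number from compound 1 to compound 4 (0.10 log units; within the scatter) is a small rise in clearance, within the usual scatter. For compound 4 the estimated clearance is 14 mL/min/kg with an expected range from 8 mL/min/kg to 26 mL/min/kg as its limits.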

Compound 4, clearance: < 8 mL/min/kg
Compound 4 gave a limit, no number (the forecaster's own chance of this, stated with the estimate: 20%); middle value at least 1.7-fold (0.24 log units) from the limit.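

In this assay, placing the group of 9 heavy atoms where compound 1 carries the group of 7 heavy atoms gives an at least 1.3-fold lower number from compound 1 to compound 4 (0.13 log units; that floor lies within the scatter). This first single-place comparison shows that, at this position meta to an isopropoxy group, the change brings no rise in clearance. The result for compound 4 is a limit of the assay, so the full size of the step cannot be read: the limit of < 8 mL/min/kg in this assay, at which 3 of the 4 values shown sit.

The compounds shown leave open whether an amine or a longer chain on this six-membered aromatic ring with 2 hetero atoms would behave in the same way.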